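Aziridine carboxamides on leukemia cells: removing the para fluorine

This account rests on a few compounds, and the source may have more. Where it says the series, first, only, none or still open, it means among the compounds named here.

Measured so far:
compound 1, `N#CC1CN1C(=O)Nc1ccc(F)cc1`: 5900 nM
compound 2, `N#CC1CN1C(=O)Nc1ccc(Cl)cc1Cl`: 33000 nM

In a functional assay on L1210 cells (Mus musculus) for inhibition, read by MTT assay (a lower number here means a stronger inhibitor, a higher number a weaker inhibitor), compound 1 gives 5900 nM, the lower of the two numbers; compound 2 gives 33000 nM, a gap beyond the scatter. Nothing else is measured for the shared core.

Compound 3, `N#CC1CN1C(=O)Nc1ccccc1`, is still to be measured. Against compound 1 the difference is hydrogen in place of fluoro on an aromatic carbon. Going by the values given here, no step between two measured compounds shows the effect of taking a halogen off the ring; compound 2 carries two chlorines rather than one fluorine, so it does not isolate this change. The expectation is a small step, within or just past the scatter, most likely toward a somewhat higher number, since the only measured variation of the halogen pattern moved that way. Compound 3 is expected at 8500 nM, with a range of 3000 nM to 25000 nM, a step of a 1.4-fold higher number from compound 1 to compound 3 (0.16 log units; within the scatter).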

Compound 3, half-maximal inhibitory concentration: 11000 nM
The estimate for compound 3 lay 1.3-fold (0.11 log units) below the measured number, within the range that was stated.
By their numbers in this assay, from the lowest: compounds 1 and 3 (each within the scatter of the next); then compound 2.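

In this assay, going by these compounds alone, hydrogen in place of fluoro on the aromatic carbon gives the first step that isolates this position, with a 1.9-fold higher number from compound 1 to compound 3 (0.27 log units; within the scatter) as its size. The fluoro is thus not required to keep the number in this range: with no halogen on the ring at all, the series stays within the scatter of compound 1. Nothing available gives a reason for the size of this step.

Open, on these data alone, is how this same aromatic carbon responds to groups other than fluoro and hydrogen, such as a single chloro, a methoxy, an amine or a carboxylic acid. Within the data shown here, the two chlorines of compound 2 also remain unresolved, with no single-place step tying either one to its higher number.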